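The compounds below may be only part of what the source reports. "The series", "measured", "known", "first", "only" and "open" are said of these compounds alone.

Working notes on the series. In a functional assay on Jurkat cells (Homo sapiens) for cytotoxicity, with a stated time of 48 h (a higher number here means a weaker inhibitor, a lower number a stronger inhibitor), compound 1 (`CCOC(=O)CC1C(C(=O)OCC)=C(N)Oc2ccc(-c3ccc(C(C)(C)C)cc3)cc21`) gives 35500 nM and compound 2 (`CC(=O)NC1=CC(C)c2cc(-c3ccccc3)ccc2O1`) gives 67700 nM. These two values lie within the usual scatter of each other, so the data do not separate compound 2 from compound 1. Both numbers indicate weak inhibition in this assay.

Compound 3 (`CC(=O)N(C(C)=O)C1=CC(C)c2cc(-c3ccccc3)ccc2O1`) has not yet been measured and differs from compound 2 in one place: acetyl in place of hydrogen on an amide-type nitrogen. In words, this is acetyl in place of hydrogen on an amide-type nitrogen, which can also be read as acetamido to diacetylamino.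

Among the measured compounds shown here, no measured pair shows what a change of this kind does in this assay. For the measured compounds named here, the only anchor is therefore compound 2 at 67700 nM, and no shift beyond the scatter is expected, with no firm direction. The estimated change is a 1.2-fold lower number from compound 2 to compound 3 (0.09 log units; within the scatter), a small step that remains uncertain. For compound 3 the expected value is 55000 nM, with an estimated range of 22000 nM to 120000 nM.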

Compound 3, half-maximal inhibitory concentration: 70600 nM
Beside the measured number, compound 3's estimate is 1.3-fold (0.11 log units) below it, within the range that was stated.
By their numbers in this assay, from the lowest: compounds 1, 2 and 3 (each within the scatter of the next).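

The pair formed by compound 2 and compound 3 gives the series its first one-place comparison: in this assay, acetyl in place of hydrogen on an amide-type nitrogen gives a 1.0-fold higher number from compound 2 to compound 3 (0.02 log units; within the scatter), so the data do not separate the acetamido compound from the diacetylamino compound. At this position, then, the amide hydrogen can give way to a second acetyl with no change in the read-out that stands clear of the scatter, a point the comparison of compound 1 and compound 2 could not make, since those two differ in more than one place. No independent measurement on these compounds bears on why the step is this small.

As far as these compounds go, only acetyl has been seen on this nitrogen, so it remains open whether a longer chain such as hexanoyl, or an acyl group ending in a carboxylic acid, would move the number beyond the scatter. From the compounds shown here alone, it is equally open whether the same step would read alike on the core of compound 1, since this single pair speaks only for the core shared by compound 2 and compound 3.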